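Benzyl in Place of Cyclohexylmethyl on a Biphenyl Carbamate

This account rests on a few compounds, and the source may have more. Where it says the series, first, only, none or still open, it means among the compounds named here.

Measured compounds:
compound 1, `O=C(Nc1cccc(-c2ccc(C(F)(F)F)cc2)c1)OCc1ccccc1`: 9410 nM
compound 2, `O=C(Nc1cccc(-c2ccc(F)cc2)c1)OCC1CCCCC1`: 26700 nM

In an assay on B16-F10 cells for inhibition of Monoglyceride lipase (Mus musculus), read by fluorescence, with stated times of 60 min, 2.5 min and 2 h (on this read-out higher numbers stand for weaker inhibition and lower numbers for stronger inhibition), compound 2 gives 26700 nM, the highest of the two numbers measured. Its nearest neighbour is compound 1, which in this assay gives 9410 nM, a gap beyond the usual scatter. Compound 3, `O=C(Nc1cccc(-c2ccc(F)cc2)c1)OCc1ccccc1`, carries phenyl in place of cyclohexyl on a saturated chain carbon bound to an oxygen next to a carbonyl group relative to compound 2. Among the compounds with values here, no measured pair isolates this change, so the step is uncertain; compound 3 is expected to move to a lower number by a modest step, a 1.8-fold lower number from compound 2 to compound 3 (0.25 log units; within the scatter), close to the edge of the scatter. For compound 3 the estimate in this assay is 15000 nM, with a range from 5000 nM to 45000 nM.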

Compound 3, half-maximal inhibitory concentration: 15600 nM
Compound 3: the middle estimate sits 1.0-fold (0.02 log units) below what was measured; the measured number falls inside the stated range.
By their numbers in this assay, from the lowest: compounds 1, 3 and 2 (each within the scatter of the next, the first and the last beyond it).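

In this assay the change from cyclohexyl to phenyl at this position gives a 1.7-fold lower number from compound 2 to compound 3 (0.23 log units; within the scatter) and so does not separate the two rings. Fluoro in place of trifluoromethyl on an aromatic carbon gives a 1.7-fold higher number from compound 1 to compound 3 (0.22 log units; within the scatter) and does not separate those two groups either. Compound 3 thus links compound 1 and compound 2 through single changes, each within the scatter. Nothing given here offers a reason for either step. As far as these compounds go, whether an amine or a longer chain at this position would give a step beyond the scatter stays open.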